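This account rests on a few compounds, and the source may have more. Where it says the series, first, only, none or still open, it means among the compounds named here.

Working notes on the series. Two compounds share the core and a three-carbon chain carrying a hydroxyl; they differ only in the group on the chain end. In a functional assay on MCF7 cells (Homo sapiens) for antiproliferative activity, read by MTT assay, with a stated time of 24 h, tested at 50 uM (on this read-out higher numbers stand for a weaker effect at the one concentration tested and lower numbers for a stronger effect), compound 1 `COc1cccc(C(O)CCn2nc3c(Br)c(Br)c(Br)c(Br)c3n2)c1` gives 22%. In this assay compound 2 `OC(CCn1nc2c(Br)c(Br)c(Br)c(Br)c2n1)c1cccc(Cl)c1` gives 28%. Among the compounds with values here, the one measured step, a number 6 percentage points higher from compound 1 to compound 2 (within the scatter), is the exchange of chloro for methoxy on the aromatic carbon and is within the scatter, so compound 2 stands with the higher of the two numbers in this assay only nominally, and no ordering between compound 1 and compound 2 is claimed.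

Compound 3 `CC(O)CCn1nc2c(Br)c(Br)c(Br)c(Br)c2n1` is the next compound. Its change from compound 2 is methyl in place of 3-chlorophenyl on a saturated chain carbon bound to an oxygen on a saturated carbon and a saturated chain carbon. Within the data shown here, no measured step bears on this change: the one step in hand touched only a substituent on the aromatic ring that is now removed altogether, and it stayed within the scatter. The step is therefore unconstrained by the data, and the step of a number 17 percentage points higher from compound 2 to compound 3 (beyond the scatter) in this assay is an expectation carrying a wide range rather than a reading of any measured trend. For compound 3 the expected value in this assay is 45%, with a range from 20% to 75%.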

Compound 3, a percentage reported as activity, at one concentration (the size of the read-out at that concentration, not a potency): 90%
Beside the measured number, compound 3's estimate is 45 percentage points below it, and the stated range ends below it.
By their numbers in this assay, from the lowest: compounds 1 and 2 (each within the scatter of the next); then compound 3.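

In this assay, methyl in place of 3-chlorophenyl on a saturated chain carbon bound to an oxygen on a saturated carbon and a saturated chain carbon gives a number 62 percentage points higher from compound 2 to compound 3 (beyond the scatter), and methyl in place of 3-methoxyphenyl at the same place gives a number 68 percentage points higher from compound 1 to compound 3 (beyond the scatter). The earlier exchange of a substituent on the aromatic ring stayed within the scatter, whereas these two large steps show that, at the one concentration tested, the effect depends strongly on which group occupies this place: with either substituted phenyl group the effect is much stronger than with methyl. The data in hand give no explanation for this large weakening of the effect.

The compounds shown leave open whether the aromatic ring itself matters or whether any larger group at this place would do, since methyl is the only group without a ring among them. An unsubstituted phenyl, a cyclohexyl or a longer alkyl chain at this carbon would separate these readings, and a carbonyl in place of the hydroxyl would test the neighbouring oxygen.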